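The compounds below may be only part of what the source reports. "The series", "measured", "known", "first", "only" and "open" are said of these compounds alone.

Of the compounds shown here, three have so far been measured in an assay on HEK293 cells for positive allosteric modulation of metabotropic glutamate receptor 2 (Rattus norvegicus), read by thallium flux, with a stated time of 2.5 min; a higher number here means that more compound is needed for the effect, a lower number that less compound is needed. Compound 1 `Cc1c(OCCCCOc2ccc(F)c(C(=O)O)c2)ccc(C(=O)CC(C)(C)C)c1O` gives 208 nM, compound 2 `COc1cc(C(=O)O)ccc1OCCCCOc1ccc(C(=O)CC(C)(C)C)c(O)c1C` gives 47 nM, and compound 3 `CC(=O)c1ccc(OCCCCOc2ccc(F)c(C(=O)O)c2)c(C)c1O` gives 259 nM. Compound 3 differs from compound 1 in a single place, (hydrogen in place of tert-butyl on a saturated chain carbon bound to a carbonyl carbon), and the resulting step of a 1.2-fold higher number from compound 1 to compound 3 (0.10 log units; within the scatter) lies within the scatter of repeated measurements, so the two values cannot be told apart. Compound 2 has a different core from compound 1, and that difference between the two cores is not broken down here. Compound 4 `COc1cc(C(=O)O)ccc1OCCCCOc1ccc(C(C)=O)c(O)c1C` has not yet been measured. Among the measured compounds shown here, it differs from compound 2 by hydrogen in place of tert-butyl on a saturated chain carbon bound to a carbonyl carbon, which is the same change, at the same place, as the one separating compound 1 and compound 3. Because the measured step of a 1.2-fold higher number from compound 1 to compound 3 (0.10 log units; within the scatter) was small, a similarly small step is expected here, a 1.2-fold higher number from compound 2 to compound 4 (0.07 log units; within the scatter). Compound 4 is therefore estimated to give about 55 nM, most likely falling between 25 nM and 130 nM.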

Compound 4, half-maximal effective concentration: 161 nM
Compound 4: middle estimate off by 2.9-fold (0.47 log units), on the low side; measured number above the stated range.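

On the core of compound 2, putting hydrogen in place of tert-butyl gives, in this assay, a 3.4-fold higher number from compound 2 to compound 4 (0.53 log units; beyond the scatter), whereas the same change made no measurable difference on the core of compound 1. A step measured on one core therefore cannot simply be carried over to the other in this series, as the two steps show when set side by side: the same change on two cores in this assay, a 1.2-fold higher number (0.10 log units; within the scatter) from compound 1 to compound 3 and a 3.4-fold higher number (0.53 log units; beyond the scatter) from compound 2 to compound 4, 2.8-fold (0.44 log units) apart, beyond the scatter of two such steps This rests on just two pairs of compounds, however; it does not show which difference between the two cores matters or why the steps differ, and it says nothing about how the change would behave on a third core.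

From the compounds shown here alone, it remains open how a methyl or an isopropyl in place of the tert-butyl, on the same saturated chain carbon bound to a carbonyl carbon, would behave on each core. Going by these compounds, it is also open whether an amine or a longer chain at that carbon would show the same dependence on the core.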